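The compounds below may be only part of what the source reports. "The series", "measured", "known", "first", "only" and "open" are said of these compounds alone.

Measured compounds:
compound 1, `COc1ccc(CNc2nc3cc(N)cc(N)c3nc2-c2ccccc2)cc1OC` — in a functional assay on MOLT-4 cells (Homo sapiens) for inhibition, read by sulforhodamine B assay, with a stated time of 48 h (on this read-out lower numbers stand for stronger inhibition of growth and higher numbers for weaker inhibition of growth), compound 1 gives only a limit, < 100000 nM.
compound 2, `Nc1cc(N)c2nc(-c3ccccc3)c(NCc3ccc(F)cc3)nc2c1` — in this assay compound 2 likewise gives only a limit, < 100000 nM.

Both values are limits of the assay, not numbers, so compound 2 stands nowhere on a scale: it is known only to sit at the limit of < 100000 nM in this assay, at which 2 of the 2 values shown sit. Among the measured compounds shown here, the single measured step, a step that the two limits leave unreadable from compound 1 to compound 2, stays unreadable because both of its ends rest on (the limit of < 100000 nM in this assay, at which 2 of the 2 values shown sit).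

Compound 3, `Nc1cc(N)c2nc(-c3ccccc3)c(Oc3ccc(F)cc3)nc2c1`, carries the change (4-fluorophenoxy in place of (4-fluorobenzyl)amino on an aromatic carbon). For the measured compounds named here, no measured step touches this exchange of the linking nitrogen for oxygen; the one step in the set, from the dimethoxyphenyl to the fluorophenyl, gives no size. The expectation for compound 3 therefore rests on nothing beyond its two measured neighbours, both at the same limit. Compound 3 is estimated at 60000 nM, within 6000 nM to 150000 nM, most probably again reported as a limit. The implied step is expected to be a step that the limit leaves unreadable from compound 2 to compound 3, none beyond the scatter.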

Compound 3, concentration for total growth inhibition: < 100000 nM
Compound 3 ended at the assay's limit (the forecaster's own chance of this, stated with the estimate: 70%); the middle value is on the limit's open side.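

In this assay compound 3 gives < 100000 nM, a limit and not a number. No step can be read between compound 2 and compound 3, as all values rest on one limit: the limit of < 100000 nM in this assay, at which 3 of the 3 values shown sit. From the compounds shown here alone, whether 4-fluorophenoxy and (4-fluorobenzyl)amino differ at all, and the actual values of compounds 1, 2 and 3, stay open.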